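Aryloxy swap on the diaminoquinoxaline-type core: a dichloro-to-fluoro step

The source may hold more compounds than are shown below. What is called first, only, known or untested is meant among the compounds shown, and "the series" means these compounds.

Measured so far, in a functional assay on MCF7 cells (Homo sapiens) for inhibition, read by sulforhodamine B assay, with a stated time of 48 h; a higher number here means a weaker inhibitor of growth, a lower number a stronger inhibitor of growth:
compound 1 `Nc1cc(N)c2nc(-c3ccccc3)c(Oc3ccc(Cl)c(Cl)c3)nc2c1` gives 14100 nM
compound 2 `CCOC(=O)[C@H](CCC(=O)O)NC(=O)c1ccc(CNc2nc3cc(N)cc(N)c3nc2-c2ccccc2)cc1` gives < 100000 nM
compound 3 `CCOC(=O)[C@H](CCC(=O)O)NC(=O)c1ccc(Sc2nc3cc(N)cc(N)c3nc2-c2ccccc2)cc1` gives 5750 nM

The value of compound 2 is a limit of this assay and not a number (the limit of < 100000 nM in this assay, at which 1 of the 3 values shown sits). Of the two numbers in hand, compound 1 carries the highest; the nearest is compound 3, whose lower number sits beyond the scatter. Among the compounds with values here, no step between measured compounds that differ in a single place is at hand, so the pair compound 1 and compound 3 can only be read as two values, not as a measured step.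

Compound 4 `Nc1cc(N)c2nc(-c3ccccc3)c(Oc3ccc(F)cc3)nc2c1` is still to be measured. It differs from compound 1 in one place: 4-fluorophenyl in place of 3,4-dichlorophenyl on an oxygen on an aromatic ring whose other neighbour is an aromatic carbon. Within the data shown here, no measured step covers such a change, so the expectation rests on the position of compound 1 alone. The step of a 1.8-fold higher number from compound 1 to compound 4 (0.25 log units; within the scatter) is expected to be small to modest, most likely toward a higher number, though a step within the scatter cannot be excluded. For compound 4 the estimated value in this assay is 25000 nM, with an expected range from 8000 nM to 80000 nM.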

Compound 4, concentration for 50% growth inhibition: 20400 nM
For compound 4 the middle estimate is 1.2-fold (0.09 log units) above the measured one; low and high end bracket the measured number.
By their numbers in this assay, from the lowest: compound 3; then compounds 1 and 4 (each within the scatter of the next).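

In this assay, the series now has its first step between compounds that differ in one place, and it reads a 1.4-fold higher number from compound 1 to compound 4 (0.16 log units; within the scatter). Within the data shown here, with the step inside the scatter, 4-fluorophenyl in place of 3,4-dichlorophenyl on an oxygen on an aromatic ring gives no readable gain or loss in growth inhibition, so this particular exchange of one halogenated phenyl for another leaves the read-out at this position effectively unchanged, which the earlier compounds, none of them a single-place pair, could not show. Nothing in hand bears on the reason for this result.

From the compounds shown here alone, both aryl groups compared here carry only halogen on the phenyl ring, so it remains open whether this position responds at all to a different kind of group, such as a phenoxy bearing an amine or a carboxylic acid, or a longer chain on the oxygen in place of the aromatic ring. Also open, going by these compounds, is whether the same exchange would read the same way in a compound with a different substituent elsewhere on the shared core, since a single step on a single pair cannot establish a trend.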